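The compounds below may be only part of what the source reports. "The series", "measured", "known", "first", "only" and "open" are said of these compounds alone.

Measured in an ADME assay on WI-38 cells (Homo sapiens) for cytotoxicity, read by MTT assay, with a stated time of 3 days (a higher number here means a weaker inhibitor, a lower number a stronger inhibitor), so far:
compound 1 `O=C1c2ccccc2C(=O)N1C/C=C\Cn1cc(C#Cc2ccc(Br)cc2)c(=O)[nH]c1=O` gives 47000 nM
compound 2 `CCCCCC#Cc1cn(C/C=C/CN2C(=O)c3ccccc3C2=O)c(=O)[nH]c1=O` gives 40000 nM

Compound 1 has the higher of these two numbers, but its gap to compound 2 lies within the scatter, so the two compounds count as alike in this assay. Compound 3 `CCCCc1ccc(C#Cc2cn(C/C=C\CN3C(=O)c4ccccc4C3=O)c(=O)[nH]c2=O)cc1` differs from compound 1 in one place: butyl in place of bromo on an aromatic carbon. For the measured compounds named here, no measured pair shows this kind of swap, so there is no guide to its effect; the expectation is a step of a 1.2-fold lower number from compound 1 to compound 3 (0.07 log units; within the scatter) that stays within the scatter. Compound 3 is therefore estimated at 40000 nM, with a likely range from 15000 nM to 100000 nM.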

Compound 3, half-maximal inhibitory concentration: 17000 nM
For compound 3 the middle estimate is 2.4-fold (0.37 log units) above the measured one, within the range that was stated.
By their numbers in this assay, from the lowest: compound 3; then compounds 2 and 1 (each within the scatter of the next).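

In this assay butyl in place of bromo gives a 2.8-fold lower number from compound 1 to compound 3 (0.44 log units; beyond the scatter) and so a modest step beyond the scatter. For the compounds shown here, this is the first sign that the group on this aromatic carbon, para to a large group, can move the number, since compound 1 and compound 2 differ in more than one place and offered no such single change. No available measurement explains the step. On these data alone, whether a longer chain, an amine or a carboxylic acid at this position would lower the number further remains open.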